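The source may hold more compounds than are shown below. What is called first, only, known or untested is meant among the compounds shown, and "the series" means these compounds.

Measured in a functional assay on MDA-MB-231 cells (Homo sapiens) for cytotoxicity, read by ELISA, with a stated time of 2 days; on this read-out lower numbers stand for stronger inhibition and higher numbers for weaker inhibition:
compound 1 `Oc1cccc(-c2cc(-c3ccccc3)cc(-c3ccccc3)n2)c1`: 19300 nM
compound 2 `Oc1cccc(-c2cc(-c3ccccc3)cc(-c3ccncc3)n2)c1`: 10400 nM
compound 3 `Oc1ccc(-c2cc(-c3ccccc3)cc(-c3ccccc3)n2)cc1`: 1300 nM

Of these three, compound 3 has the lowest number, and a 15-fold lower number from compound 1 to compound 3 (1.17 log units; beyond the scatter) is the large step among them. That step swaps 3-hydroxyphenyl for 4-hydroxyphenyl, so it does not touch the group changed next. Compound 4 `Oc1ccc(-c2cc(-c3ccccc3)cc(-c3ccco3)n2)cc1` keeps the 4-hydroxyphenyl group of compound 3 and differs in one place: furan-2-yl in place of phenyl on an aromatic carbon. The nearest guide is a replacement of phenyl by pyridin-4-yl, a 1.9-fold lower number from compound 1 to compound 2 (0.27 log units; within the scatter). Among the compounds with values here, no furan-2-yl compound has been measured, so this guide is indirect. On that basis, no step beyond the scatter is expected in this assay. The expected change is a 1.1-fold lower number from compound 3 to compound 4 (0.03 log units; within the scatter). Compound 4 is estimated at 1200 nM, within an expected range of 400 nM to 3600 nM.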

Compound 4, half-maximal inhibitory concentration: 1400 nM
For compound 4 the middle estimate is 1.2-fold (0.07 log units) below the measured one; low and high end bracket the measured number.
By their numbers in this assay, from the lowest: compounds 3 and 4 (each within the scatter of the next); then compounds 2 and 1 (each within the scatter of the next).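

In this assay, furan-2-yl in place of phenyl next to the ring nitrogen gives a 1.1-fold higher number from compound 3 to compound 4 (0.03 log units; within the scatter), so a five-membered aromatic ring with 1 hetero atom serves here as well as a six-membered aromatic ring of carbon only. Within the data shown here, until now, a change at this position had been seen only with the 3-hydroxyphenyl group; this step shows a change there with the 4-hydroxyphenyl group also staying within the scatter. Nothing available explains this result. The compounds shown leave open whether an amine or a carboxylic acid at this position would hold the number, and whether furan-2-yl would behave the same with the 3-hydroxyphenyl group.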